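Swapping the amide amine on a thiophene-bearing dihydropyrimidinone

The compounds below may be only part of what the source reports. "The series", "measured", "known", "first", "only" and "open" are said of these compounds alone.

Measured compounds:
compound 1 `CC1=C(C(=O)NC(C)C)C(c2ccco2)NC(=O)N1` — 3%
compound 2 `CCN(CC)C(=O)C1=C(C)NC(=O)NC1c1ccco1` — 11%
compound 3 `CC1=C(C(=O)NC(C)C)C(c2cccs2)NC(=O)N1` — 2%

All three were tested in an assay on membranes from CHO cells for displacement of a labelled ligand from adenosine receptor A1 (Homo sapiens), read by scintillation counting, with a stated time of 60 min, tested at 1 uM; a lower number here means less inhibition, a higher number more inhibition at the concentration tested (going by the name of the read-out). Compound 1 and compound 2 share a core and differ in one place, (diethylamino in place of isopropylamino on a carbonyl carbon), and the step of a number 8 percentage points higher from compound 1 to compound 2 (within the scatter). Compound 1 and compound 3 differ in the aromatic group on the core, (thiophen-2-yl in place of furan-2-yl on a saturated ring carbon), and the step of a number 1 percentage points lower from compound 1 to compound 3 (within the scatter). The three values therefore sit together in the low range, with no difference that can be told apart from repeat-to-repeat noise.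

Compound 4 `CCN(CC)C(=O)C1=C(C)NC(=O)NC1c1cccs1` has not yet been measured in this assay. It stands to compound 3 as compound 2 stands to compound 1: diethylamino in place of isopropylamino on a carbonyl carbon. The place lines for the two changes are the same word for word, so this is the same change, made on a core that differs as described for compound 1 and compound 3.

Because the earlier step of a number 8 percentage points higher from compound 1 to compound 2 (within the scatter) stayed within the scatter, the expected step of a number 6 percentage points higher from compound 3 to compound 4 (within the scatter) is small. Compound 4 is estimated at 8% in this assay, with a likely range from 0% to 20%.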

Compound 4, a percentage reported as inhibition, at one concentration (the size of the read-out at that concentration, not a potency): 13%
Compound 4: the middle estimate sits 5 percentage points below what was measured, and the stated range covers the measured number.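

Carrying diethylamino in place of isopropylamino over to the core with thiophen-2-yl gives a number 11 percentage points higher from compound 3 to compound 4 (beyond the scatter), and this step cannot be told apart from the one on the core with furan-2-yl: the same change on two cores in this assay, a number 8 percentage points higher (within the scatter) from compound 1 to compound 2 and a number 11 percentage points higher (beyond the scatter) from compound 3 to compound 4, 3 percentage points apart, within the scatter of two such steps. With diethylamino in place, thiophen-2-yl in place of furan-2-yl gives a number 2 percentage points higher from compound 2 to compound 4 (within the scatter), and this step also matches its earlier counterpart: the same change on two cores in this assay, a number 1 percentage points lower (within the scatter) from compound 1 to compound 3 and a number 2 percentage points higher (within the scatter) from compound 2 to compound 4, 3 percentage points apart, within the scatter of two such steps. Among these compounds, the amine change therefore carries over between these two cores, although only the step on the core with thiophen-2-yl lies beyond the scatter, and this rests on just two pairs of compounds read at a single concentration, so it shows neither a potency nor how the change would behave on any other core.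

The compounds shown leave open what ethylamino, or a longer chain such as dipropylamino, would do on the carbonyl carbon in this assay. They also leave open whether a phenyl group on the saturated ring carbon would fit the same picture.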